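Removing the para-methoxy from the pendant aryl of compound 3

The source may hold more compounds than are shown below. What is called first, only, known or untested is meant among the compounds shown, and "the series" means these compounds.

Measured in a functional assay on WM 266-4 cells (Homo sapiens) for inhibition, read by MTT assay, with a stated time of 24 h; a lower number here means a stronger inhibitor of growth, a higher number a weaker inhibitor of growth:
compound 1 `COc1ccc(C2=NN(C(=O)c3ccc4c(c3)OCCO4)C(c3ccccc3)C2)cc1` — 2370 nM
compound 2 `O=C(c1ccc2c(c1)OCCO2)N1N=C(c2ccccc2)CC1c1ccc(F)cc1` — 5210 nM
compound 3 `COc1ccc(C2CC(c3ccccc3)=NN2C(=O)c2ccc3c(c2)OCCO3)cc1` — 8370 nM

Compound 3 gives the highest of the three numbers in this assay, but its nearest neighbour is compound 2, and the step of a 1.6-fold higher number from compound 2 to compound 3 (0.21 log units; within the scatter) is within the scatter, so the two cannot be ordered. Only compound 1, a positional isomer of compound 3 in which the methoxyphenyl and phenyl rings trade places on the shared core, stands clearly apart with its lower number.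

Compound 4 `O=C(c1ccc2c(c1)OCCO2)N1N=C(c2ccccc2)CC1c1ccccc1` has not yet been measured. It differs from compound 3 by hydrogen in place of methoxy on an aromatic carbon; cut one bond further out, the change reads 4-methoxyphenyl to phenyl. Going by the values given here, no measured step removes a substituent from this position. Among the compounds with values here, the one step that bears on it, a 1.6-fold higher number from compound 2 to compound 3 (0.21 log units; within the scatter), swaps fluoro for methoxy at the same aromatic carbon and stays within the scatter, which suggests that this position tolerates small changes without much effect on growth inhibition. On that basis compound 4 is expected to land close to compound 3, with an estimated step of a 1.3-fold lower number from compound 3 to compound 4 (0.11 log units; within the scatter), perhaps slightly toward the value of compound 2. The estimate for compound 4 in this assay is therefore 6500 nM, with a range from 2700 nM to 16000 nM.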

Compound 4, concentration for 50% growth inhibition: 1370 nM
Compound 4: middle estimate off by 4.7-fold (0.68 log units), on the high side; measured number below the stated range.
By their numbers in this assay, from the lowest: compounds 4 and 1 (each within the scatter of the next); then compounds 2 and 3 (each within the scatter of the next).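

In this assay going to hydrogen gives a 6.1-fold lower number from compound 3 to compound 4 (0.79 log units; beyond the scatter) and shows that this aromatic carbon, para to a large group, is not indifferent to what it carries, which the swap of fluoro for methoxy alone could not reveal. Removing fluoro from the same carbon points the same way, with a 3.8-fold lower number from compound 2 to compound 4 (0.58 log units; beyond the scatter) so among these three compounds hydrogen stands apart from both fluoro and methoxy, while those two substituents cannot be ordered. Removing the methoxy from the other aromatic ring of the shared core reads differently: with a 1.7-fold lower number from compound 1 to compound 4 (0.24 log units; within the scatter) the two compounds cannot be ordered, so the change from 4-methoxyphenyl to phenyl shows a clear step on one ring and no readable step on the other.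

Only hydrogen, fluoro and methoxy are shown on this carbon, so it remains open whether an amine, a carboxylic acid or a longer chain such as ethoxy would fall with compound 4 or with compound 2 and compound 3. No measurement at hand accounts for the gap between hydrogen and these two substituents.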